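From methylamino to ureido on the shared core

This account rests on a few compounds, and the source may have more. Where it says the series, first, only, none or still open, it means among the compounds named here.

In a functional assay on K562 cells (Homo sapiens) for cytotoxicity, read by MTT assay, with a stated time of 3 days (a lower number here means a stronger inhibitor, a higher number a weaker inhibitor), compound 1 `N#Cc1c(Nc2ccccc2)nc(SCc2nc3ccccc3[nH]2)nc1-c1ccccc1` gives 3.2 nM and compound 3 `CCNc1nc(SCc2nc3ccccc3[nH]2)nc(-c2ccccc2)c1C#N` gives 4.38 nM while compound 2 `CNc1nc(SCc2nc3ccccc3[nH]2)nc(-c2ccccc2)c1C#N` stands highest of the three at 13.2 nM on these numbers. Compound 4 `N#Cc1c(NC(N)=O)nc(SCc2nc3ccccc3[nH]2)nc1-c1ccccc1` differs from compound 2 by carbamoyl in place of methyl on a nitrogen on an aromatic ring with carbamoyl in place of methyl on a nitrogen on an aromatic ring. Among the compounds with values here, two measured steps bear on that nitrogen. One is a 3.0-fold lower number from compound 2 to compound 3 (0.48 log units; beyond the scatter) and the other, read in the opposite direction, is a 4.1-fold higher number from compound 1 to compound 2 (0.62 log units; beyond the scatter) and both are modest. In both, the group other than methyl goes with the lower number, but neither compound carries carbamoyl. The expected change in this assay is therefore modest and towards a lower number, estimated as a 1.7-fold lower number from compound 2 to compound 4 (0.22 log units; within the scatter) although the range allows either direction. The estimate for compound 4 is 8 nM with 2 nM to 30 nM as its expected range.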

Compound 4, half-maximal inhibitory concentration: 4.54 nM
Beside the measured number, compound 4's estimate is 1.8-fold (0.25 log units) above it; measured number inside the range.
By their numbers in this assay, from the lowest: compounds 1, 3 and 4 (each within the scatter of the next); then compound 2.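

In this assay, carbamoyl on this nitrogen gives a 2.9-fold lower number from compound 2 to compound 4 (0.46 log units; beyond the scatter), so a group with a carbonyl also departs from methyl in the same direction as ethyl and phenyl. Carbamoyl shows a 1.0-fold higher number from compound 3 to compound 4 (0.02 log units; within the scatter) and a 1.4-fold higher number from compound 1 to compound 4 (0.15 log units; within the scatter), leaving methyl in compound 2 as the only one of these four groups set apart from the others. No measurement given here accounts for this step. Still open, from the compounds shown here alone, is whether an unsubstituted amine, a propyl chain or an acetyl group on this nitrogen would sit with compound 2 or with compounds 1, 3 and 4.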